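A Ring Closure on the Acid-Bearing Side Chain

This account rests on a few compounds, and the source may have more. Where it says the series, first, only, none or still open, it means among the compounds named here.

Compound 3 `O=C(O)CCCCc1ccc(OCc2ccc3ccccc3n2)cc1` stands at the highest of the three measured numbers in an assay on membranes from lung (Cavia porcellus) for binding affinity to cysteinyl leukotriene receptor (Homo sapiens) (on this read-out higher numbers stand for weaker inhibition and lower numbers for stronger inhibition), where compound 3 gives 110 nM. Compound 1 `c1ccc2nc(COc3ccc(OCCCc4nnn[nH]4)cc3)ccc2c1` gives 69 nM, and the step of a 1.6-fold higher number from compound 1 to compound 3 (0.20 log units; within the scatter) stays within the scatter. Going by the values given here, compound 2 `CC(CCC(=O)O)Cc1ccc(OCc2ccc3ccccc3n2)cc1` gives 43 nM, and the step of a 2.6-fold higher number from compound 2 to compound 3 (0.41 log units; beyond the scatter) is the only one that separates compound 3 from another compound by more than the usual variation.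

Compound 4 `O=C(O)C1CCC(c2ccc(OCc3ccc4ccccc4n3)cc2)C1` differs from compound 3 by 3-carboxycyclopentyl in place of 4-carboxybutyl on an aromatic carbon. All three measured steps also alter this acid-bearing side chain, so all of them bear on the change. The steps of a 1.6-fold lower number from compound 1 to compound 2 (0.21 log units; within the scatter) and a 1.6-fold higher number from compound 1 to compound 3 (0.20 log units; within the scatter) were within the scatter, while the step of a 2.6-fold higher number from compound 2 to compound 3 (0.41 log units; beyond the scatter) was modest: a single added carbon on the chain went with a somewhat lower number. Closing the chain into a five-membered ring adds one carbon in a comparable place, so a step of roughly that size toward a lower number is expected, with a real chance of no step beyond the scatter.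

Compound 4 is therefore expected to give about 60 nM, with a likely range from 25 nM to 150 nM, which would mean an estimated step of a 1.8-fold lower number from compound 3 to compound 4 (0.26 log units; within the scatter).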

Compound 4, inhibition constant: 43 nM
Compound 4: middle estimate off by 1.4-fold (0.14 log units), on the high side; low and high end bracket the measured number.
By their numbers in this assay, from the lowest: compounds 2, 4, 1 and 3 (each within the scatter of the next, the first and the last beyond it).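

Replacing the open 4-carboxybutyl chain with the 3-carboxycyclopentyl ring gives a modest but real shift in this assay (a 2.6-fold lower number from compound 3 to compound 4 (0.41 log units; beyond the scatter)), so this position responds to closing the chain as well as to adding a methyl group to it. The ring and the methyl-branched chain cannot be told apart here (no change at the digits printed from compound 2 to compound 4 (within the scatter)), and the tetrazole-bearing side chain also stays within the usual variation of the ring (a 1.6-fold lower number from compound 1 to compound 4 (0.21 log units; within the scatter)), which places three differently built side chains in one band, with only the unbranched acid chain of compound 3 lying clearly apart from compounds 2 and 4. Nothing measured here explains why the ring and the methyl-branched chain go with the same number.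

As far as these compounds go, it remains open whether a larger ring, such as a carboxycyclohexyl group, would keep the number of compound 4 or lose it. From the compounds shown here alone, it is equally open whether a 1H-tetrazol-5-yl group in place of the carboxylic acid on the five-membered ring would fit in the same band, as the tetrazole of compound 1 does on its open chain.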